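Trifluoromethyl in Place of Methoxy on Compound 3

The source may report more compounds than this note shows. Statements on the series, on what has been measured and on what is new or still open speak of the compounds shown alone.

In a functional assay on MCF7 cells (Homo sapiens) for antiproliferative activity, with a stated time of 5 days (on this read-out lower numbers stand for stronger inhibition and higher numbers for weaker inhibition), compound 1 (`CCCCc1ccc2[nH]c(-c3ccc(C(F)(F)F)cc3)c(C=O)c2c1`) stands at 66 nM and compound 2 (`CCCCc1ccc2[nH]c(-c3ccc(OC)cc3)c(/C=N/O)c2c1`) at 212 nM while compound 3 (`CCCCc1ccc2[nH]c(-c3ccc(OC)cc3)c(/C=N/NC(=O)c3ccccc3)c2c1`) stands at 130 nM and so lies within the scatter of both. Compound 3 therefore cannot be ranked against either of them.

Compound 4 (`CCCCc1ccc2[nH]c(-c3ccc(C(F)(F)F)cc3)c(/C=N/NC(=O)c3ccccc3)c2c1`) departs from compound 3 at one place, with trifluoromethyl in place of methoxy on an aromatic carbon para to a large group. Going by the values given here, the one measured step (a 1.6-fold lower number from compound 2 to compound 3 (0.21 log units; within the scatter)) puts benzamido in place of hydroxy on a double-bonded nitrogen, which is a different change at a different place. Among the compounds with values here, it stayed small, but it says nothing direct about the new change, and no measured pair isolates methoxy against trifluoromethyl. Compound 1 carries trifluoromethyl and gives 66 nM but also differs from compound 3 at a second place, so it offers no clear direction. The expected outcome is a 1.2-fold lower number from compound 3 to compound 4 (0.07 log units; within the scatter) and thus no step beyond the scatter. For compound 4 the estimated value is 110 nM with an expected range from 40 nM to 300 nM in the same measurement.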

Compound 4, half-maximal inhibitory concentration: 460 nM
Beside the measured number, compound 4's estimate is 4.2-fold (0.62 log units) below it; measured number above the stated range.
By their numbers in this assay, from the lowest: compounds 1, 3 and 2 (each within the scatter of the next, the first and the last beyond it); then compound 4.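

In this assay, going by these compounds alone, the change from 4-methoxyphenyl to 4-(trifluoromethyl)phenyl can now be read on its own for the first time, and with the benzamido side held constant it gives a 3.5-fold higher number from compound 3 to compound 4 (0.55 log units; beyond the scatter) as the size of the change at this place, so this aromatic carbon is not indifferent to which of the two groups it carries. With trifluoromethyl held constant, the other end of the molecule also counts: putting the group of 11 heavy atoms in place of the group of 2 heavy atoms gives a 7.0-fold higher number from compound 1 to compound 4 (0.84 log units; beyond the scatter) on that side, a step beyond the scatter at a place where the methoxy pair of compound 2 and compound 3, which carries a different change, stayed within it. No measurement here accounts for either step.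

The compounds shown leave open whether the methoxy to trifluoromethyl step keeps its direction and size when the benzamido side is replaced by the aldehyde or the oxime, since each of those appears with only one of the two groups. They also leave open how a methyl, a chlorine or an amine on this aromatic carbon would read against methoxy and trifluoromethyl.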